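The compounds below may be only part of what the source reports. "The series", "measured", "known", "first", "only" and "open" are said of these compounds alone.

In a functional assay on KB cells (Homo sapiens), with a stated time of 72 h (on this read-out lower numbers stand for stronger inhibition and higher numbers for weaker inhibition), two compounds that share one core have been measured so far: compound 1 `Cc1nc2cc([C@@H]3C[C@@H]4O[C@]4(C)CCC[C@H](C)[C@H](O)[C@@H](C)C(=O)C(C)(C)[C@@H](O)CC(=O)O3)ccc2s1` gives 0.09 nM, and compound 2 `Cc1nc2cc([C@@H]3C[C@@H]4O[C@]4(C)CCC[C@H](C)[C@H](O)[C@@H](C)C(=O)C(C)(C)[C@@H](O)CC(=O)O3)ccc2n1C` gives 0.38 nM. Compound 2 therefore holds the higher of the two numbers, which makes it the weaker inhibitor of this pair, although both values are very small.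

Compound 3 `C[C@H]1CCC[C@@]2(C)O[C@H]2C[C@@H](c2ccc3cccnc3c2)OC(=O)C[C@H](O)C(C)(C)C(=O)[C@H](C)[C@H]1O` keeps the same core and differs only in the group on the saturated ring carbon next to the ring oxygen: a group of 10 heavy atoms (9 carbon, 1 nitrogen; one six-membered aromatic ring of carbon only, one six-membered aromatic ring with 1 hetero atom) in place of a group of 11 heavy atoms (9 carbon, 2 nitrogen; one five-membered aromatic ring with 2 hetero atoms, one six-membered aromatic ring of carbon only), on a saturated ring carbon. Quinolin-7-yl enters there, so one aromatic group with two fused rings is replaced by another.

For the measured compounds named here, only one measured step bears on this change, as it is also an exchange of such a group at the same carbon: a 4.2-fold higher number from compound 1 to compound 2 (0.63 log units; beyond the scatter). That step was modest, and a single example gives no firm direction for the new exchange. A step of similar or smaller size therefore seems likely, and the expected 1.3-fold lower number from compound 2 to compound 3 (0.10 log units; within the scatter) lies within the usual scatter. Compound 3 is estimated at 0.3 nM, with an expected range from 0.1 nM to 1 nM.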

Compound 3, half-maximal inhibitory concentration: 0.1 nM
Compound 3: the middle estimate sits 3.0-fold (0.48 log units) above what was measured, within the range that was stated.
By their numbers in this assay, from the lowest: compounds 1 and 3 (each within the scatter of the next); then compound 2.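

In this assay the saturated ring carbon next to the ring oxygen now carries a third aromatic group with two fused rings, and quinolin-7-yl in place of the group of compound 2 gives a 3.8-fold lower number from compound 2 to compound 3 (0.58 log units; beyond the scatter) as the step, which takes the number back down to the level of compound 1. Set against the 2-methyl-1,3-benzothiazol-5-yl of compound 1, the same group gives a 1.1-fold higher number from compound 1 to compound 3 (0.05 log units; within the scatter) as the step, so a five-membered aromatic ring in the fused group is not required here, and among these three only compound 2 stands apart from the other two. Nothing measured here explains why the group of compound 2 gives the higher number.

All three groups shown hold two fused aromatic rings, so it remains open how a single phenyl ring or a plain alkyl chain would behave on this carbon. Also open, going by these compounds, is whether the result depends on where the ring nitrogen sits, as a quinolin-6-yl group at this carbon would show.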